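The compounds below may be only part of what the source reports. "The series", "measured", "known", "first", "only" and "open" are said of these compounds alone.

In a functional assay (a lower number here means a stronger inhibitor, a higher number a weaker inhibitor), compound 1 `CC(C)=CCOc1cc(O)c2c(c1)OC(c1ccccc1F)CC2=O` gives 5300 nM and compound 2 `CC(C)=CCOc1cc(O)c2c(c1)OC(c1ccc(Br)cc1)CC2=O` gives 2770 nM, so compound 2 stands within the usual scatter of compound 1. Compound 3 `CC(C)=CCOc1cc(O)c2c(c1)OC(c1ccc(O)cc1)CC2=O` keeps the rest of compound 2 and differs by hydroxy in place of bromo on an aromatic carbon. Among the compounds with values here, the only measured step, a 1.9-fold lower number from compound 1 to compound 2 (0.28 log units; within the scatter), swaps a different pair of groups, and no measured compound carries this hydroxy group. The expected change is therefore no larger than the scatter, an estimated 1.1-fold higher number from compound 2 to compound 3 (0.03 log units; within the scatter). For compound 3 the estimated value is 3000 nM, with an expected range of 1000 nM to 9000 nM.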

Compound 3, half-maximal inhibitory concentration: 5340 nM
For compound 3 the middle estimate is 1.8-fold (0.25 log units) below the measured one; low and high end bracket the measured number.
By their numbers in this assay, from the lowest: compounds 2, 1 and 3 (each within the scatter of the next).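

Hydroxy in place of bromo on this aromatic carbon gives a 1.9-fold higher number from compound 2 to compound 3 (0.29 log units; within the scatter) in this assay, so the swap from a halogen to a group with a hydrogen-bond donor and acceptor does not shift the result beyond normal variation. Moving from 2-fluorophenyl to 4-hydroxyphenyl gives a 1.0-fold higher number from compound 1 to compound 3 (0.00 log units; within the scatter), so all three aryl groups remain indistinguishable in this assay. No available evidence explains these results. Going by these compounds, it remains open whether an amine or a carboxylic acid at this aromatic carbon would give a step beyond the scatter.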